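A few compounds are considered here, and "the series" means these few. Any claim that something is new, unique, unknown or untested is made for them only; others in the source may bear on it.

Compound 1, `Cc1cccc2c1[n+]([O-])nc(N)[n+]2[O-]`, is one of three measured members of this set, and in a physicochemical assay for lipophilicity (on this read-out higher numbers stand for higher lipophilicity and lower numbers for lower lipophilicity), compound 1 gives 0.24. Compound 2, `Nc1n[n+]([O-])c2c(Cl)cccc2[n+]1[O-]`, differs from it by a single change, (chloro in place of methyl on an aromatic carbon), and in this assay compound 2 gives 0.17. The step between the two is a number 0.07 log units lower from compound 1 to compound 2 (within the scatter), so the pair shows the two values lying close together. Compound 3, `Cc1ccc2c(c1)[n+]([O-])nc(N)[n+]2[O-]`, has the same atoms as compound 1 joined differently; the difference between the two cores is not broken down here. In this assay compound 3 gives 0.13, a number close to those of compound 1 and compound 2.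

Compound 4, `Nc1n[n+]([O-])c2cc(Cl)ccc2[n+]1[O-]`, is not yet measured. It stands to compound 3 as compound 2 stands to compound 1, through (chloro in place of methyl on an aromatic carbon). The surroundings of the place differ, however: in the pair of compound 1 and compound 2 the aromatic carbon is ortho to a fused ring and meta to a fused ring, whereas in the pair of compound 3 and compound 4 it is meta to a fused ring and para to a fused ring, so this is the same kind of change rather than the same change. The expectation for compound 4 in this assay therefore rests on the step from compound 1 to compound 2, which is a number 0.07 log units lower from compound 1 to compound 2 (within the scatter), and a step of about a number 0.07 log units lower from compound 3 to compound 4 (within the scatter) is expected because the earlier step of a number 0.07 log units lower from compound 1 to compound 2 (within the scatter) was small. On that basis compound 4 is estimated at 0.06, with a likely range from -0.24 to 0.36.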

Compound 4, partition coefficient: 0.44
For compound 4 the middle estimate is 0.38 log units below the measured one, and the stated range ends below it.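

In this assay, for the compounds shown here, the exchange of methyl for chloro on an aromatic carbon does not carry over as one fixed step: on the core of compound 3 it gives a number 0.31 log units higher from compound 3 to compound 4 (beyond the scatter), whereas on the core of compound 1 it gave a number 0.07 log units lower from compound 1 to compound 2 (within the scatter), so only the step on the core of compound 3 stands clear of the scatter. This shows that, within these two pairs, the result of the change depends on where it is made, but it does not show whether the core itself, the place on the ring or the two together set the size of the step, since the pairs differ in both and two pairs cannot separate them. Nothing among the results shown gives a measured reason for the difference between the two steps.

The compounds shown leave open whether another group in the same place, such as fluoro, methoxy or a carboxylic acid, would follow the step seen with chloro on the core of compound 3 or the one seen on the core of compound 1. They also leave open what the amine on the shared core contributes, as an ethylamine or an acetamide in its place does not appear among them.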